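The source may report more compounds than this note shows. Statements on the series, on what has been measured and on what is new or still open speak of the compounds shown alone.

Among the measured compounds shown here, compound 2 `N#Cc1c(N)n(CC2CC2)c2ccc(Oc3ccc(NC(=O)CN)cc3)cc12` is one of two compounds measured in an assay on isolated protein for inhibition of arsenite methyltransferase (Homo sapiens), with stated times of 30 min and 90 min, in the presence of a further agent that is not named here; a lower number here means a stronger inhibitor, a higher number a weaker inhibitor; compound 2 gives 1500 nM, while compound 1 `Cn1c(N)c(C#N)c2cc(OCc3cccc(N)c3)ccc21` gives 1400 nM, two values that lie within the usual scatter of each other, so neither stands apart. Compound 3 `N#Cc1c(N)n(CC(N)=O)c2ccc(Oc3ccc(NC(=O)CN)cc3)cc12` differs from compound 2 in one place: carbamoyl in place of cyclopropyl on a saturated chain carbon bound to an aromatic nitrogen. For the measured compounds named here, no measured pair shows this change, so nothing is known about its effect. The expected step of a 1.2-fold higher number from compound 2 to compound 3 (0.08 log units; within the scatter) is modest, or none beyond the scatter. Compound 3 is estimated at 1800 nM in this assay, with a range from 600 nM to 5500 nM.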

Compound 3, half-maximal inhibitory concentration: 20000 nM
Beside the measured number, compound 3's estimate is 11-fold (1.05 log units) below it, outside the stated range (above it).
By their numbers in this assay, from the lowest: compounds 1 and 2 (each within the scatter of the next); then compound 3.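

In this assay, the position on a saturated chain carbon bound to an aromatic nitrogen proves sensitive: carbamoyl in place of cyclopropyl, with the same count of heavy atoms, gives a 13-fold higher number from compound 2 to compound 3 (1.12 log units; beyond the scatter) in a single change. Compound 1 and compound 2 could not show this, as they differ in more than one place. Nothing available explains the size of this step.

On these data alone, whether an amine, a carboxylic acid or a longer carbon chain here would keep the value of compound 2 stays open. This single pair also leaves open whether carbamoyl would act the same way in other compounds.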